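Compound 2 and a Swap from Hydroxy to Piperidin-1-yl

The source may hold more compounds than are shown below. What is called first, only, known or untested is meant among the compounds shown, and "the series" means these compounds.

- compound 1 `NS(=O)(=O)c1ccccc1-c1ccc(C(=O)NCCC(=O)Nc2ccc(Br)cn2)cc1`: 2.67%
- compound 2 `NS(=O)(=O)c1ccccc1-c1ccc(C(=O)NC(CC(=O)Nc2ccc(Br)cn2)C(=O)O)cc1`: 4%

Both numbers come from an in vivo ADME assay on the whole organism (Rattus norvegicus) for pharmacokinetics; on this read-out lower numbers stand for lower oral bioavailability and higher numbers for higher oral bioavailability. Compound 2, at 4%, stands level with compound 1 once the usual scatter is allowed for. Compound 3 `NS(=O)(=O)c1ccccc1-c1ccc(C(=O)NC(CC(=O)Nc2ccc(Br)cn2)C(=O)N2CCCCC2)cc1` has not yet been measured. It carries piperidin-1-yl in place of hydroxy on a carbonyl carbon, which turns the carboxy of compound 2 into (piperidin-1-yl)carbonyl: piperidin-1-yl in place of hydroxy on a carbonyl carbon. Going by the values given here, only one measured step bears on this, the one that brought in that carboxy: a number 1.3 percentage points higher from compound 1 to compound 2 (within the scatter). Among the compounds with values here, no measured step shows piperidin-1-yl entering, so the guide is thin, and only a small rise in this assay is expected. The expected step is a number 2 percentage points higher from compound 2 to compound 3 (within the scatter). For compound 3 the estimate is 6%, with an expected range from 1% to 16%.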

Compound 3, oral bioavailability: 2.7%
For compound 3 the middle estimate is 3.3 percentage points above the measured one; low and high end bracket the measured number.
By their numbers in this assay, from the lowest: compounds 1, 3 and 2 (each within the scatter of the next).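

In this assay, piperidin-1-yl in place of hydroxy on a carbonyl carbon gives a number 1.3 percentage points lower from compound 2 to compound 3 (within the scatter), so swapping the carboxy for (piperidin-1-yl)carbonyl, with its six-membered non-aromatic ring, leaves the read-out within the scatter. Set against the plain chain of compound 1, the same group in place of hydrogen gives a number 0 percentage points higher from compound 1 to compound 3 (within the scatter), so hydrogen, carboxy and (piperidin-1-yl)carbonyl on this chain carbon now all stand level in this assay. No measurement is at hand that would explain this levelness.

The compounds shown leave open whether a different group on this chain carbon, such as an amine or a methyl ester, would give a number beyond the scatter from compound 1. They also leave open whether a change elsewhere on the shared core would do so.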